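Phenoxy series: methoxy position on the outer ring

The source may report more compounds than this note shows. Statements on the series, on what has been measured and on what is new or still open speak of the compounds shown alone.

Compound 2 `COc1cccc(Oc2ccc([C@H]3S[C@@H](C)C(=O)Nc4c3c(C)nn4-c3ccccc3C)cc2)c1` stands highest of the two numbers in an assay on isolated protein for agonist activity at Bile acid receptor (Homo sapiens), read by AlphaScreen, with a stated time of 30 min; on this read-out higher numbers stand for larger maximal responses and lower numbers for smaller maximal responses; compound 2 gives 120%. Within the data shown here, its only measured neighbour, compound 1 `CCOc1cccc(-c2ccc([C@H]3S[C@@H](C)C(=O)Nc4c3c(C)nn4-c3ccccc3C)cc2)c1`, gives 13% in this assay, a step of a number 107 percentage points higher from compound 1 to compound 2 (beyond the scatter). Compound 3 `COc1ccccc1Oc1ccc([C@H]2S[C@@H](C)C(=O)Nc3c2c(C)nn3-c2ccccc2C)cc1` differs from compound 2 by 2-methoxyphenyl in place of 3-methoxyphenyl on an oxygen on an aromatic ring. Among the measured compounds shown here, no measured step isolates this move of the methoxy group; the single step alters the linking oxygen as well, so it bears only loosely on it. With the linking oxygen kept, compound 3 is expected to stay near compound 2, with a step of a number 25 percentage points lower from compound 2 to compound 3 (beyond the scatter) and an estimate of 95% within 40% to 130%.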

Compound 3, largest response reached (reported as efficacy), in percent of the reference or control that the assay uses: 240%
The estimate for compound 3 lay 145 percentage points below the measured number; measured number outside the range, above it.
By their numbers in this assay, from the lowest: compound 1; then compound 2; then compound 3.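

Moving the methoxy group on the outer ring, with the atoms unchanged, is enough to shift the response in this assay: a number 120 percentage points higher from compound 2 to compound 3 (beyond the scatter). The linking oxygen therefore does not set the level alone, and 2-methoxyphenoxy gives the largest gain over the biaryl ether of this set: a number 227 percentage points higher from compound 1 to compound 3 (beyond the scatter). No supporting data explain why this move raises the response. Open, from the compounds shown here alone, is whether an amine or a carboxylic acid in place of the methoxy group keeps this response. Also open, going by these compounds, is whether 2-methoxyphenyl holds it without the linking oxygen.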